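This account rests on a few compounds, and the source may have more. Where it says the series, first, only, none or still open, it means among the compounds named here.

Going by the values given here, compound 1, with the structure `CCCCCCCO/N=C/c1cc(OC)c2c(c1OC)C(=O)C=CC2=O`, is the first of three measured compounds. In a functional assay on A549 cells (Homo sapiens) for antiproliferative activity (on this read-out higher numbers stand for an effect only at larger amounts of compound and lower numbers for an effect already at smaller amounts), compound 1 reaches only the limit of the assay, > 10 ug/mL. Compound 2, `CCCCCO/N=C/c1cc(OC)c2c(c1OC)C(=O)C=CC2=O`, differs from compound 1 by hydrogen in place of ethyl on a saturated chain carbon, five bonds along the chain from an oxygen on an unsaturated carbon. In this assay compound 2 likewise gives only a limit, > 10 ug/mL. The step that the two limits leave unreadable from compound 1 to compound 2 therefore has no readable size, since both ends are limits rather than numbers. Compound 3, `CCCCCCCO/N=C(\CCCCCC)c1cc(OC)c2c(c1OC)C(=O)C=CC2=O`, carries a different core from compound 1; the difference between the two cores is not broken down here. In this assay compound 3 also reaches only the limit, > 10 ug/mL. Compound 1, compound 2 and compound 3 all sit at the limit of > 10 ug/mL in this assay, at which 3 of the 3 values shown sit, so no ordering among them can be drawn.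

Compound 4, `CCCCCC/C(=N\OCCCCC)c1cc(OC)c2c(c1OC)C(=O)C=CC2=O`, has not been measured. Among the compounds with values here, it differs from compound 3 by hydrogen in place of ethyl on a saturated chain carbon, five bonds along the chain from an oxygen on an unsaturated carbon, which is the same change, at the same place, as the one from compound 1 to compound 2. Because that earlier change left both partners at the limit of > 10 ug/mL in this assay, at which 3 of the 3 values shown sit, compound 4 is expected to stay at the limit as well, which amounts to an estimated step that the limit leaves unreadable from compound 3 to compound 4. On that basis the expected value for compound 4 in this assay is 20 ug/mL, with an estimated range from 10 ug/mL to 60 ug/mL.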

Compound 4, concentration for half-maximal effect: > 10 ug/mL
Compound 4 was reported as a limit; the forecaster's own chance of this, stated with the estimate: 85%; the middle value lies beyond the limit too.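

In this assay compound 4 gives > 10 ug/mL as a limit of the assay, not a number. Going by these compounds alone, with compound 3 also at a limit, no step between compound 3 and compound 4 can be read, and all the compounds shown sit together: (the limit of > 10 ug/mL in this assay, at which 4 of the 4 values shown sit). The compounds shown leave open how strong any of them is, and whether replacing ethyl with hydrogen at this place on the chain changes the effect at all.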